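The compounds below may be only part of what the source reports. "The series", "measured", "known", "first", "only" and "open" are said of these compounds alone.

Series notes. In a functional assay on MGC-803 cells (Homo sapiens) for cytotoxicity, read by MTT assay, with a stated time of 72 h (a higher number here means a weaker inhibitor, a lower number a stronger inhibitor), compound 1 `FC(F)(F)c1ccc(CSc2nc(Nc3ccccc3C(F)(F)F)c3ccccc3n2)cc1` returns only a limit, > 50000 nM, as the limit of > 50000 nM in this assay, at which 1 of the 3 values shown sits. Compound 2 `Cc1ccccc1Nc1nc(SCc2ccc(C(F)(F)F)cc2)nc2ccccc12` gives 24400 nM in this assay, and compound 3 `FC(F)(F)c1ccc(CSc2nc(Nc3ccc(C(F)(F)F)cc3)c3ccccc3n2)cc1` gives 6170 nM, the lowest number of the two measured. The two cores differ as 4-(trifluoromethyl)phenyl in place of 2-(trifluoromethyl)phenyl on a nitrogen on an aromatic ring, a step of an at least 8.1-fold lower number from compound 1 to compound 3 (0.90 log units; beyond the scatter); the step of a 4.0-fold lower number from compound 2 to compound 3 (0.60 log units; beyond the scatter) runs the same way. Compound 4 `Cc1ccc(Nc2nc(SCc3ccc(C(F)(F)F)cc3)nc3ccccc23)cc1` is not yet measured. It differs from compound 3 by methyl in place of trifluoromethyl on an aromatic carbon, a change occurring twice in the set and of the same kind as methyl in place of trifluoromethyl on an aromatic carbon, which gave an at least 2.0-fold lower number from compound 1 to compound 2 (0.31 log units; beyond the scatter); the place is not the same, ortho to a large group there and para to a large group here. A step of a 1.5-fold lower number from compound 3 to compound 4 (0.19 log units; within the scatter) is expected for compound 4, resting on an at least 2.0-fold lower number from compound 1 to compound 2 (0.31 log units; beyond the scatter). Compound 4 is estimated at 4000 nM, between 1500 nM and 12000 nM.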

Compound 4, half-maximal inhibitory concentration: 36100 nM
Beside the measured number, compound 4's estimate is 9.0-fold (0.96 log units) below it, and the stated range ends below it.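

In this assay, methyl in place of trifluoromethyl, para to a large group, gives a 5.9-fold higher number from compound 3 to compound 4 (0.77 log units; beyond the scatter), and the change does not carry from one core to another with a common direction: the same change on two cores in this assay, an at least 2.0-fold lower number (0.31 log units; beyond the scatter) from compound 1 to compound 2 and a 5.9-fold higher number (0.77 log units; beyond the scatter) from compound 3 to compound 4, at least 11-fold (1.07 log units) apart, beyond the scatter of two such steps

With methyl on both, 4-methylphenyl in place of 2-methylphenyl gives a 1.5-fold higher number from compound 2 to compound 4 (0.17 log units; within the scatter), so this pair is not separated. With 4-methylphenyl in place of 2-(trifluoromethyl)phenyl, the data give an at least 1.3-fold lower number from compound 1 to compound 4 (0.14 log units; that floor lies within the scatter). Compound 1 gives only a limit, and the two pairs set no rule for any other core: the limit of > 50000 nM in this assay, at which 1 of the 4 values shown sits.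

Open, on these data alone, is whether a chlorine, a methoxy group or a carboxylic acid in place of the trifluoromethyl would track compound 3 or compound 4. Also open, as far as these compounds go, is whether the reversal appears outside this assay.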